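A Second Fluorine on the Aryl Group and Cell Tolerance

This account rests on a few compounds, and the source may have more. Where it says the series, first, only, none or still open, it means among the compounds named here.

Compound 1 `O=c1cc(-c2ccccc2)oc2c(-c3ccc(F)cc3)c(O)c(O)c(O)c12` was tested in a toxicity assay on Huh-7 cells (Homo sapiens) for cytotoxicity, read by CCK-8 assay, with a stated time of 24 h; a higher number here means that more compound is tolerated, a lower number that less compound is tolerated. In this assay compound 1 gives > 100000 nM, which is a limit of the assay rather than a measured number. Two other compounds share the same core. Compound 2 `CN1CCN(c2ccc(-c3cc(=O)c4c(O)c(O)c(O)cc4o3)cc2)CC1` gives > 100000 nM in this assay, again a limit. Compound 3 `Oc1c(O)c(O)c2c(=S)cc(-c3ccccc3)oc2c1-c1ccc(C(F)(F)F)cc1` gives > 100000 nM, also a limit. So compound 1 does not stand out in any direction: all three results sit at the limit of > 100000 nM in this assay, at which 3 of the 3 values shown sit, and no number separates them.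

Compound 4 `O=c1cc(-c2ccccc2)oc2c(-c3cc(F)cc(F)c3)c(O)c(O)c(O)c12` has not yet been tested. It differs from compound 1 in one place, (3,5-difluorophenyl in place of 4-fluorophenyl on an aromatic carbon). The leaving group and the entering group are alike in ring, in donors and acceptors and in charge, and differ by one fluorine. Because every result so far lies at the limit of > 100000 nM in this assay, at which 3 of the 3 values shown sit, no direction of change can be read from these compounds, and the step from compound 1 to compound 4 is expected to be none beyond the scatter, a step that the limit leaves unreadable from compound 1 to compound 4. For compound 4 the expected result in this assay is 150000 nM, with a range from 60000 nM to 400000 nM, and most likely it will again be reported only as a limit.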

Compound 4, half-maximal cytotoxic concentration: > 100000 nM
Compound 4 ended at the assay's limit; the forecaster's own chance of this, stated with the estimate: 80%; the middle value lies beyond the limit too.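

In this assay compound 4 gives > 100000 nM, which is a limit and not a number. Going by these compounds alone, compound 1 also sits at a limit, and no step between compound 1 and compound 4 can be read. All results shown stand at the same point: the limit of > 100000 nM in this assay, at which 4 of the 4 values shown sit.

The compounds shown leave open what concentration would harm these cells, and whether 3,5-difluorophenyl in place of 4-fluorophenyl changes it.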